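Notes on compound 4: a carbonyl substituent step

The compounds below may be only part of what the source reports. "The series", "measured", "known", "first", "only" and "open" are said of these compounds alone.

Compound 3 `COc1cc(C(=O)N2CCN(C(=O)c3cc(OC)c(OC)c(OC)c3)C(COC(=O)CC(C)(C)C)C2)cc(OC)c1OC` gives 120 nM in a functional assay (Oryctolagus cuniculus) for inhibition of platelet-activating factor receptor (Cavia porcellus) (a lower number here means a stronger inhibitor, a higher number a weaker inhibitor), the lowest of the three measured numbers. Compound 1 `CCCCCCCC(=O)OCC1CN(C(=O)c2cc(OC)c(OC)c(OC)c2)CCN1C(=O)c1cc(OC)c(OC)c(OC)c1` gives 310 nM and compound 2 `COc1cc(C(=O)N2CCN(C(=O)c3cc(OC)c(OC)c(OC)c3)C(COC(=O)C3CCCCC3)C2)cc(OC)c1OC` gives 290 nM; the steps of a 2.6-fold lower number from compound 1 to compound 3 (0.41 log units; beyond the scatter) and a 2.4-fold lower number from compound 2 to compound 3 (0.38 log units; beyond the scatter) are modest and beyond the scatter, while a 1.1-fold lower number from compound 1 to compound 2 (0.03 log units; within the scatter) lies within it. Compound 4 `CCCCN(CCCC)C(=O)OCC1CN(C(=O)c2cc(OC)c(OC)c(OC)c2)CCN1C(=O)c1cc(OC)c(OC)c(OC)c1` differs from compound 3 by dibutylamino in place of neopentyl on a carbonyl carbon. All three measured steps vary the group on that carbonyl carbon, and together they span only the gap from compound 3 to compound 1; none of them places a nitrogen there. A modest step back toward the numbers of compound 1 and compound 2 is therefore expected: a 2.1-fold higher number from compound 3 to compound 4 (0.32 log units; beyond the scatter). Compound 4 is estimated at 250 nM, with a range from 80 nM to 800 nM.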

Compound 4, half-maximal inhibitory concentration: 1250 nM
The estimate for compound 4 lay 5.0-fold (0.70 log units) below the measured number; the measured number lies above the stated range.
By their numbers in this assay, from the lowest: compound 3; then compounds 2 and 1 (each within the scatter of the next); then compound 4.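

Dibutylamino on this carbonyl carbon, the only nitrogen placed there, gives the one large step at this position in this assay: a 10-fold higher number from compound 3 to compound 4 (1.02 log units; beyond the scatter). The other two steps are modest, a 4.3-fold higher number from compound 2 to compound 4 (0.63 log units; beyond the scatter) and a 4.0-fold higher number from compound 1 to compound 4 (0.61 log units; beyond the scatter), so all three groups joined through carbon give lower numbers than dibutylamino, whether chain, ring or branched. Nothing available here accounts for this change.

From the compounds shown here alone, the nitrogen and the two butyl chains enter together, so their shares remain open. Dimethylamino or piperidine on the same carbonyl carbon would bear on that.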